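Adding Fluorine to a Weak Thiosemicarbazone

The compounds below may be only part of what the source reports. "The series", "measured", "known", "first", "only" and "open" are said of these compounds alone.

Of the compounds shown here, two have been measured so far. Compound 1 `CNc1c(F)ccc2c(C=NNC(=S)N(C)C)nccc12` gives 272 nM in a functional assay on MIA PaCa-2 cells (Homo sapiens) for cytotoxicity, read by luminescence, with a stated time of 72 h; a higher number here means a weaker inhibitor, a lower number a stronger inhibitor. Compound 2 `CN(C)C(=S)NN=Cc1nccc2ccccc12` gives 29600 nM in this assay, the highest of the two numbers and a gap to compound 1 well beyond the scatter. Compound 3 `CN(C)C(=S)NN=Cc1nccc2cc(F)ccc12` differs from compound 2 by fluoro in place of hydrogen on an aromatic carbon. Within the data shown here, compound 1 differs from compound 2 in more than one place, so no single-change step is known, and no shift beyond the scatter is expected from the fluoro alone. Compound 3 is therefore expected to give 20000 nM, within 8000 nM to 50000 nM, a step of a 1.5-fold lower number from compound 2 to compound 3 (0.17 log units; within the scatter).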

Compound 3, concentration for 90% inhibition: 111 nM
Compound 3: middle estimate off by 180-fold (2.26 log units), on the high side; the whole stated range lies above it.
By their numbers in this assay, from the lowest: compound 3; then compound 1; then compound 2.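

In this assay, this one aromatic carbon proves highly sensitive: fluoro in place of hydrogen gives a 270-fold lower number from compound 2 to compound 3 (2.43 log units; beyond the scatter), so a single atom separates a weak compound from a strong one. Hydrogen in place of methylamino gives a 2.5-fold lower number from compound 1 to compound 3 (0.39 log units; beyond the scatter), so the methylamino group is not needed for this strength once the fluoro is present. Nothing available here explains why the fluoro has so large an effect. Going by these compounds, whether chloro or methoxy on this carbon would match fluoro remains open, as does what methylamino would do without the fluoro.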